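The compounds below may be only part of what the source reports. "The series", "measured", "known", "first", "only" and "open" are said of these compounds alone.

Measured in an assay (Cricetulus griseus) for inhibition of aldehyde dehydrogenase, mitochondrial (Homo sapiens); on this read-out lower numbers stand for stronger inhibition and higher numbers for weaker inhibition:
compound 1 `CCOC(=O)COc1ccc2c(=O)c(-c3ccc(O)cc3)coc2c1`: 130 nM
compound 2 `CCOC(=O)CCCCOc1ccc2c(=O)c(-c3ccc(O)cc3)coc2c1`: 240 nM
compound 3 `O=C(O)COc1ccc2c(=O)c(-c3ccc(O)cc3)coc2c1`: 1200 nM

Compound 3 stands at the highest number of the three; the steps of a 9.2-fold higher number from compound 1 to compound 3 (0.97 log units; beyond the scatter) and a 5.0-fold higher number from compound 2 to compound 3 (0.70 log units; beyond the scatter) both lie beyond the scatter, while a 1.8-fold higher number from compound 1 to compound 2 (0.27 log units; within the scatter) lies within it. Compound 4 `O=c1c(-c2ccc(O)cc2)coc2cc(OCCOCCOCCO)ccc12` carries (2-(2-hydroxyethoxy)ethoxy)methyl in place of carboxy on a saturated chain carbon bound to an oxygen on an aromatic ring. The two steps that lead into compound 3 bear on this change: each one brought in the carboxy that compound 4 now loses, and each raised the number by a modest amount, whereas lengthening the ester chain from compound 1 to compound 2 changed little. For compound 4 a move back toward the numbers of compounds 1 and 2 is therefore expected, estimated as a 5.5-fold lower number from compound 3 to compound 4 (0.74 log units; beyond the scatter). Compound 4 is expected to give 220 nM in this assay, with a range from 80 nM to 600 nM.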

Compound 4, half-maximal inhibitory concentration: 40 nM
For compound 4 the middle estimate is 5.5-fold (0.74 log units) above the measured one; measured number outside the range, below it.
By their numbers in this assay, from the lowest: compound 4; then compounds 1 and 2 (each within the scatter of the next); then compound 3.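

In this assay, the chain on the saturated chain carbon bound to an oxygen on an aromatic ring does more than lose the penalty of the carboxy: 2-(2-(2-hydroxyethoxy)ethoxy)ethyl gives a 30-fold lower number from compound 3 to compound 4 (1.48 log units; beyond the scatter). It also passes both esters, with a 6.0-fold lower number from compound 2 to compound 4 (0.78 log units; beyond the scatter) and a 3.3-fold lower number from compound 1 to compound 4 (0.51 log units; beyond the scatter), so an ester carbonyl is not needed here for the lowest number in the series. Nothing available accounts for this drop.

Going by these compounds, it remains open whether the ether oxygens or the terminal hydroxyl carry the effect. A plain hexyl chain, a terminal methyl ether or a terminal amine would separate these.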